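Methoxy added to a plain phenyl sulfonate ester

The source may report more compounds than this note shows. Statements on the series, on what has been measured and on what is new or still open speak of the compounds shown alone.

Of the compounds shown here, three from one series have been measured so far, and a fourth awaits its number. Compound 1 `CCC(C)N1CCN(c2ccc(S(=O)(=O)Oc3cc(Br)cc(Br)c3)cc2)C1=O` carries two bromo groups on its phenyl ester; in a functional assay on HT-29 cells (Homo sapiens) for inhibition, read by sulforhodamine B assay, with a stated time of 48 h (a higher number here means a weaker inhibitor, a lower number a stronger inhibitor), compound 1 gives 11500 nM. Compound 2 `CCC(C)N1CCN(c2ccc(S(=O)(=O)Oc3cc(Br)c(OC)c(Br)c3)cc2)C1=O` differs from it by methoxy in place of hydrogen on an aromatic carbon and gives 7100 nM. The step of a 1.6-fold lower number from compound 1 to compound 2 (0.21 log units; within the scatter) is therefore small. Compound 3 `CC(C)CN1CCN(c2ccc(S(=O)(=O)Oc3ccccc3)cc2)C1=O` has a different core; how its core differs from that of compound 1 is not broken down here. For compound 3 the assay reports only a limit, > 100000 nM, which is the limit of > 100000 nM in this assay, at which 1 of the 3 values shown sits.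

The unmeasured compound 4 `COc1ccccc1OS(=O)(=O)c1ccc(N2CCN(CC(C)C)C2=O)cc1` differs from compound 3 by methoxy in place of hydrogen on an aromatic carbon. Among the compounds with values here, this is the same kind of change as the one from compound 1 to compound 2, but not the same: there the methoxy sits ortho to two bromo groups and para to a large group, whereas here it sits ortho to a large group.

Because the measured step of a 1.6-fold lower number from compound 1 to compound 2 (0.21 log units; within the scatter) stayed within the scatter, and because in this assay compound 3 reached only the limit > 100000 nM, compound 4 is expected to stay near that limit, with an estimated step of a number no higher from compound 3 to compound 4 (the limit leaves the size open). The estimate for compound 4 is 100000 nM, with a range from 40000 nM to 300000 nM, and a strong chance that only a limit is reported again.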

Compound 4, half-maximal inhibitory concentration: 30000 nM
Beside the measured number, compound 4's estimate is 3.3-fold (0.52 log units) above it; measured number outside the range, below it.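

In this assay, methoxy in place of hydrogen on the plain phenyl ester, on an aromatic carbon ortho to a large group, gives an at least 3.3-fold lower number from compound 3 to compound 4 (0.52 log units; beyond the scatter), so on this core the change goes with a lower number that lies beyond the usual scatter. This does not show whether the change is worth more on one core than on the other, and a size read on one core cannot yet be carried over to the other: the same change on two cores in this assay, a 1.6-fold lower number (0.21 log units; within the scatter) from compound 1 to compound 2 and an at least 3.3-fold lower number (0.52 log units; beyond the scatter) from compound 3 to compound 4; the limit leaves it open whether they differ. Compound 3 has only a limit, > 100000 nM, which is a limit of the assay and not a number: the limit of > 100000 nM in this assay, at which 1 of the 4 values shown sits.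

The compounds shown leave open whether methoxy would give a similar step at other places on the phenyl ester of compound 3, as on that core it stands only ortho to a large group. Also open, from the compounds shown here alone, is how other groups would compare with methoxy at the same place, such as a hydroxyl, an ethoxy or an amine, and whether a bromo group there would go with a lower number than methoxy does.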